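This account rests on a few compounds, and the source may have more. Where it says the series, first, only, none or still open, it means among the compounds named here.

Compound 3, with the structure `O=c1cc(CNCc2cccc(I)c2)oc2ccc(O)c(O)c12`, sits at the limit of an ADME assay on Huh-7 cells (Homo sapiens) for cytotoxicity (on this read-out higher numbers stand for lower toxicity in this test and lower numbers for higher toxicity in this test), with a reading of > 100000 nM, a limit rather than a number. Compound 1, `O=c1cc(CNCc2ccccc2Br)oc2ccc(O)c(O)c12`, also sits at a limit, giving > 100000 nM in this assay. Going by the values given here, compound 2, `O=c1cc(CNCc2ccccc2I)oc2ccc(O)c(O)c12`, is the one compound with a number, 87300 nM in this assay. Because (the limit of > 100000 nM in this assay, at which 2 of the 3 values shown sit), the step from compound 1 to compound 3 is a step that the two limits leave unreadable from compound 1 to compound 3, while the step from compound 2 to compound 3 is an at least 1.1-fold higher number from compound 2 to compound 3 (0.05 log units; that floor lies within the scatter) and the step from compound 1 to compound 2 is an at least 1.1-fold lower number from compound 1 to compound 2 (0.05 log units; that floor lies within the scatter).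

Compound 4, `O=c1cc(CNCc2ccc(O)cc2)oc2ccc(O)c(O)c12`, differs from compound 3 by 4-hydroxyphenyl in place of 3-iodophenyl on a saturated chain carbon bound to an amine nitrogen. Among the compounds with values here, the steps that bear on this change, the replacement of one ring on the saturated chain carbon bound to the amine nitrogen by another, are the two just named, and neither reaches beyond the usual scatter of this assay. Compound 4 is therefore expected to show a step of a number no higher from compound 3 to compound 4 (the limit leaves the size open) from compound 3, that is none beyond the scatter. Compound 4 is estimated at 100000 nM in this assay, within a range from 50000 nM to 200000 nM.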

Compound 4, half-maximal cytotoxic concentration: 62700 nM
Estimate against measurement, compound 4: 1.6-fold (0.20 log units) above; low and high end bracket the measured number.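

In this assay, going by these compounds alone, the pair of compound 2 and compound 4 is the first with a number at both ends, and it gives a 1.4-fold lower number from compound 2 to compound 4 (0.14 log units; within the scatter). This shows that on the saturated chain carbon bound to the amine nitrogen, 4-hydroxyphenyl, with a hydrogen-bond donor and acceptor, can take the place of a halogen-bearing ring that has neither, with no step beyond the scatter. The other two steps, an at least 1.5-fold lower number from compound 3 to compound 4 (0.20 log units; that floor lies within the scatter) and an at least 1.5-fold lower number from compound 1 to compound 4 (0.20 log units; that floor lies within the scatter), give only floors because compound 1 and compound 3 stand at a limit: the limit of > 100000 nM in this assay, at which 2 of the 4 values shown sit.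

The compounds shown leave open whether a carboxylic acid or an amine on this ring, or a longer chain between the ring and the amine nitrogen, would produce a step beyond the scatter. They also do not separate the effect of the group from that of its ring position, as 3-iodophenyl and 4-hydroxyphenyl differ in both, and a 3-hydroxyphenyl or 4-iodophenyl ring would be needed to tell the two apart.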